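Homologation of the benzylic chain: cytotoxicity notes

The compounds below may be only part of what the source reports. "The series", "measured", "known", "first", "only" and "open" are said of these compounds alone.

Measured so far:
compound 1, `CC(C)Sc1nc(O)cc(C(C)c2cccc3ccccc23)n1`, 119000 nM
compound 2, `CCC(c1cc(O)nc(SC(C)C)n1)c1cccc2ccccc12`, 16900 nM
compound 3, `CC(c1cc(O)nc(SC2CCCCC2)n1)c1c(Cl)cccc1Cl`, > 200000 nM

Three compounds of the series have been run in a functional assay on MT4 cells (Homo sapiens) for cytotoxicity; a lower number here means that less compound is tolerated, a higher number that more compound is tolerated. Compound 1, `CC(C)Sc1nc(O)cc(C(C)c2cccc3ccccc23)n1`, gives 119000 nM in this assay. Compound 2, `CCC(c1cc(O)nc(SC(C)C)n1)c1cccc2ccccc12`, gives 16900 nM. The two differ by methyl in place of hydrogen on a saturated chain carbon, two bonds along the chain from two aromatic carbons, and the step is a 7.0-fold lower number from compound 1 to compound 2 (0.85 log units; beyond the scatter), so less of compound 2 is tolerated than of compound 1.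

Compound 3, `CC(c1cc(O)nc(SC2CCCCC2)n1)c1c(Cl)cccc1Cl`, reaches only a limit of the assay, > 200000 nM, and no number. It sits at the limit of > 200000 nM in this assay, at which 1 of the 3 values shown sits. The difference between the core of compound 3 and the core of compound 1 is not broken down here.

Compound 4, `CCC(c1cc(O)nc(SC2CCCCC2)n1)c1c(Cl)cccc1Cl`, is not yet measured. It differs from compound 3 by methyl in place of hydrogen on a saturated chain carbon, two bonds along the chain from two aromatic carbons, the same change that separates compound 1 from compound 2, at the same place. If the step repeats, compound 4 is expected to be tolerated less well than compound 3, with an estimated step of an at least 3.3-fold lower number from compound 3 to compound 4 (0.52 log units; beyond the scatter), resting on the earlier step of a 7.0-fold lower number from compound 1 to compound 2 (0.85 log units; beyond the scatter). Since compound 3 is known only as a limit, the starting point is uncertain, and compound 4 may itself land at the limit. For compound 4 the estimate in this assay is 60000 nM, between 20000 nM and 200000 nM.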

Compound 4, half-maximal cytotoxic concentration: 200000 nM
Estimate against measurement, compound 4: 3.3-fold (0.52 log units) below; measured number inside the range.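

Carrying methyl in place of hydrogen over to a second core gives a number no higher from compound 3 to compound 4 (the limit leaves the size open) in this assay, and the comparison between the two cores goes only this far: the same change on two cores in this assay, a 7.0-fold lower number (0.85 log units; beyond the scatter) from compound 1 to compound 2 and a number no higher (the limit leaves the size open) from compound 3 to compound 4; the limit leaves it open whether they differ

Compound 3 gives > 200000 nM, which is a limit of the assay and not a number, so the size of the new step cannot be read: the limit of > 200000 nM in this assay, at which 1 of the 4 values shown sits.

The result is compatible with the change repeating on the second core, but it does not show that the step carries over at the same size, or that any lowering occurs there at all; the only readable size remains that of the step on the core of compound 1.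

Open, going by these compounds, is whether a longer chain, such as propyl in place of ethyl, or an amine or a carboxylic acid in the same place would continue the trend seen on the core of compound 1. Also open, on these data alone, is how the change behaves on a further core whose parent compound gives a number rather than a limit in this assay.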